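This account rests on a few compounds, and the source may have more. Where it says the series, first, only, none or still open, it means among the compounds named here.

Of the compounds shown here, three of a shared core have been measured in a functional assay on HeLa cells (Homo sapiens) for cytotoxicity, read by MTT assay, with a stated time of 2 days; a lower number here means a stronger inhibitor, a higher number a weaker inhibitor. Compound 1 `Cc1ccc2c(=O)[nH]c(-c3ccccc3F)nc2c1` gives 830 nM in this assay. Compound 2 `Cc1ccc2nc(-c3ccccc3C(F)(F)F)[nH]c(=O)c2c1` gives 2450 nM, which places it second highest of the three numbers: higher than compound 1 and lower than compound 3, with both gaps beyond the usual scatter. Compound 3 `Cc1cccc(-c2nc3cc(C)ccc3c(=O)[nH]2)c1` gives 11200 nM.

Compound 4 `Cc1ccc2nc(-c3ccccc3OC(F)(F)F)[nH]c(=O)c2c1` has not yet been measured. It differs from compound 2 in one place, on an aromatic carbon of a six-membered aromatic ring of carbon only, ortho to a large group: trifluoromethoxy in place of trifluoromethyl on an aromatic carbon. Within the data shown here, no measured pair shows the effect of this change, so the step from compound 2 to compound 4 is expected to be small, with no preferred direction beyond the scatter, as a 1.0-fold higher number from compound 2 to compound 4 (0.01 log units; within the scatter). Compound 4 is therefore estimated at 2500 nM in this assay, between 900 nM and 7000 nM.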

Compound 4, half-maximal inhibitory concentration: 850 nM
Compound 4: the middle estimate sits 2.9-fold (0.47 log units) above what was measured, outside the stated range (below it).
By their numbers in this assay, from the lowest: compounds 1 and 4 (each within the scatter of the next); then compound 2; then compound 3.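

In this assay, trifluoromethoxy in place of trifluoromethyl on this aromatic carbon, ortho to a large group, is not a neutral exchange: the change gives a 2.9-fold lower number from compound 2 to compound 4 (0.46 log units; beyond the scatter) and lies beyond the scatter. Among these compounds, no earlier pair differed in one place, so this is the only direct sign that the position responds to such a change. Nothing shown here accounts for the shift.

Going by these compounds, whether a methoxy group or an amine on the same carbon would give a lower or a higher number remains open. So does whether this step would recur on the core of compound 1.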